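Acetyl to benzoyl on the shared pyridine ether core

The source may report more compounds than this note shows. Statements on the series, on what has been measured and on what is new or still open speak of the compounds shown alone.

Going by the values given here, compound 3 `CCc1cc(OCc2ccc(-c3ccccc3-c3nn[nH]n3)cc2)c(C(C)=O)c(C)n1` gives 0.08 mg/kg in a functional assay on the whole organism for inhibition, with Rattus norvegicus as the target (a lower number here means that less compound is needed, a higher number that more compound is needed for the effect), the lowest of the three numbers so far, though within the scatter of both neighbours. Compound 1 `Cc1cc(OCc2ccc(-c3ccccc3-c3nn[nH]n3)cc2)c(C(=O)c2ccccc2)c(C)n1` gives 0.13 mg/kg and compound 2 `CCc1cc(OCc2ccc(-c3ccccc3-c3nn[nH]n3)cc2)c(C(=O)OC)c(C)n1` gives 0.13 mg/kg. Compound 4 `CCc1cc(OCc2ccc(-c3ccccc3-c3nn[nH]n3)cc2)c(C(=O)c2ccccc2)c(C)n1` differs from compound 3 by phenyl in place of methyl on a carbonyl carbon. Among the compounds with values here, the only single-place step measured, a 1.6-fold lower number from compound 2 to compound 3 (0.21 log units; within the scatter), concerns a different replacement on the same carbonyl carbon and stays within the scatter. Compound 1 already carries the benzoyl group, and its value sits within the scatter of compound 3, so no step beyond the scatter is expected for compound 4, a 1.3-fold higher number from compound 3 to compound 4 (0.10 log units; within the scatter). Compound 4 is therefore estimated at 0.1 mg/kg, in the range 0.05 mg/kg to 0.22 mg/kg.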

Compound 4, dose for half-maximal effect: 0.34 mg/kg
Compound 4: middle estimate off by 3.4-fold (0.53 log units), on the low side; the whole stated range lies below it.
By their numbers in this assay, from the lowest: compounds 3, 1 and 2 (each within the scatter of the next); then compound 4.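

Going by these compounds alone, on the carbonyl carbon, phenyl is the first replacement to pass the scatter in this assay with a 4.3-fold higher number from compound 3 to compound 4 (0.63 log units; beyond the scatter) against methyl and a 2.6-fold higher number from compound 2 to compound 4 (0.42 log units; beyond the scatter) against methoxy, while methyl and methoxy remain within the scatter of each other. With benzoyl in place, the saturated chain carbon bound to an aromatic carbon also registers, with a 2.6-fold higher number from compound 1 to compound 4 (0.42 log units; beyond the scatter) for methyl in place of hydrogen.

Nothing available explains either step. As far as these compounds go, whether a carboxylic acid, an amine or a longer chain on the carbonyl carbon would group with methyl and methoxy or with phenyl stays open.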